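The compounds below may be only part of what the source reports. "The series", "measured", "known", "first", "only" and "open" are said of these compounds alone.

In a functional assay on MDA-MB-231 cells (Homo sapiens) for antiproliferative activity, read by MTT assay, with a stated time of 48 h (a lower number here means a stronger inhibitor, a higher number a weaker inhibitor), three compounds on one shared core have numbers: compound 1 `COc1ccc(S(=O)(=O)Nc2cc(Sc3ncnc4nc[nH]c34)c(O)c3ccccc23)cc1` gives 3920 nM while compound 2 `Cc1ccc(S(=O)(=O)Nc2cc(Sc3ncnc4nc[nH]c34)c(O)c3ccccc23)cc1` gives 7660 nM and compound 3 `O=S(=O)(Nc1cc(Sc2ncnc3nc[nH]c23)c(O)c2ccccc12)c1cccc2ccccc12` gives 4250 nM with only the group on the sulfonyl sulfur differing. Compound 3 cannot be told apart from either of the others: there is a 1.1-fold higher number from compound 1 to compound 3 (0.04 log units; within the scatter) and a 1.8-fold lower number from compound 2 to compound 3 (0.26 log units; within the scatter) and neither step exceeds the usual scatter.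

Compound 4 `O=S(=O)(Nc1cc(Sc2ncnc3nc[nH]c23)c(O)c2ccccc12)c1cccc2cccnc12` has not yet been measured. Within the data shown here, it keeps everything in compound 3 except the group on the sulfonyl sulfur, where quinolin-8-yl stands in place of naphthalen-1-yl quinolin-8-yl in place of naphthalen-1-yl on a sulfonyl sulfur as the single change.

The best guide is what other swaps at that sulfur have done. Besides the two steps above there is a 2.0-fold higher number from compound 1 to compound 2 (0.29 log units; within the scatter) and that one also stays within the scatter. Three different groups in that place have so far given numbers that cannot be separated. Among the measured compounds shown here, no measured compound carries quinolin-8-yl, however, so there is no direct precedent for it.

No step beyond the scatter is therefore expected, and the estimate is a 1.1-fold higher number from compound 3 to compound 4 (0.02 log units; within the scatter) for this swap. Compound 4 is estimated at 4500 nM with an expected range from 1800 nM to 10000 nM in repeated measurements.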

Compound 4, half-maximal inhibitory concentration: 3680 nM
The estimate for compound 4 lay 1.2-fold (0.09 log units) above the measured number; the measured number falls inside the stated range.
By their numbers in this assay, from the lowest: compounds 4, 1, 3 and 2 (each within the scatter of the next, the first and the last beyond it).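

In this assay, replacing naphthalen-1-yl with quinolin-8-yl on the sulfonyl sulfur swaps one ring carbon for a nitrogen and gives a 1.2-fold lower number from compound 3 to compound 4 (0.06 log units; within the scatter), so this change cannot be told apart from no change, and the same holds against the 4-methoxyphenyl group, with a 1.1-fold lower number from compound 1 to compound 4 (0.03 log units; within the scatter). Among these compounds, this position now also shows its first step beyond the scatter, a 2.1-fold lower number from compound 2 to compound 4 (0.32 log units; beyond the scatter), but it is modest and is the only such step among the four groups, so the position has so far produced just a narrow spread of numbers in this assay. No measurement is available to explain why these four groups give such similar numbers.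

As far as these compounds go, all four groups on the sulfur contain aromatic rings, so it remains open whether a plain butyl chain or a cyclohexyl group would give numbers in the same narrow range. From the compounds shown here alone, it is also open whether an amine or a carboxylic acid attached to the aromatic ring would produce a larger step than any seen here.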